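The source may hold more compounds than are shown below. What is called first, only, known or untested is meant among the compounds shown, and "the series" means these compounds.

Compound 1 `COc1cc2c(Oc3ccc(NC(=O)c4nccc(-c5ccc(C)cc5)n4)cc3F)ccnc2cc1OCCCN1CCN(C)CC1` and compound 2 `COc1cc2c(Oc3ccc(NC(=O)c4nccc(-c5ccccc5)n4)cc3F)ccnc2cc1OCCCN1CCCC1` share one core and differ in two places. In a functional assay on HT-29 cells (Homo sapiens) for cytotoxicity, read by MTT assay, with a stated time of 72 h (on this read-out lower numbers stand for stronger inhibition and higher numbers for weaker inhibition), compound 1 gives 210 nM, and in this assay compound 2 gives 390 nM; these two numbers lie within the scatter of each other, so compound 2 stands level with compound 1. Compound 3 `COc1cc2c(Oc3ccc(NC(=O)c4nccc(-c5ccc(C)cc5)n4)cc3F)ccnc2cc1OCCCN1CCCC1` differs from compound 2 by methyl in place of hydrogen on an aromatic carbon. Within the data shown here, no measured pair shows this change on its own, so compound 3 is expected to move no further than the scatter, a 1.3-fold lower number from compound 2 to compound 3 (0.11 log units; within the scatter). The value expected for compound 3 is 300 nM, between 120 nM and 700 nM.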

Compound 3, half-maximal inhibitory concentration: 670 nM
Beside the measured number, compound 3's estimate is 2.2-fold (0.35 log units) below it; the measured number falls inside the stated range.
By their numbers in this assay, from the lowest: compounds 1, 2 and 3 (each within the scatter of the next, the first and the last beyond it).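

In this assay the change from phenyl to 4-methylphenyl gives a 1.7-fold higher number from compound 2 to compound 3 (0.24 log units; within the scatter) and so cannot be told apart from no change at this position. The group at the end of the chain shows a clearer effect: pyrrolidin-1-yl in place of 4-methylpiperazin-1-yl gives a 3.2-fold higher number from compound 1 to compound 3 (0.50 log units; beyond the scatter) and this modest step means weaker inhibition. No supporting evidence is available to explain either step.

As far as these compounds go, it remains open how chlorine or methoxy at the methyl position would compare. A morpholine ring at the chain end is likewise untested among the compounds shown.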